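This account rests on a few compounds, and the source may have more. Where it says the series, first, only, none or still open, it means among the compounds named here.

Compound 1, `CNC(=O)CCCCCCCn1nc(-c2ccc3oc(N)nc3c2)c2c(N)ncnc21`, was tested in a functional assay on A549 cells (Homo sapiens) for inhibition, read by MTT assay, with a stated time of 72 h (on this read-out higher numbers stand for weaker inhibition and lower numbers for stronger inhibition), where compound 1 gave 8360 nM. A second compound, compound 2, `Nc1ncnc2c1c(-c1cnc3[nH]ccc3c1)nn2CCCCCCCCC(=O)NO`, was run in this assay too, and compound 2 gave 12300 nM. For the measured compounds named here, compound 1 therefore holds the lowest of the two numbers, but its nearest neighbour is compound 2, whose number sits within the usual scatter of this measurement, so the two cannot be told apart on potency; the two compounds also differ in more than one place, so no single step connects them.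

Compound 3, `Nc1nc2cc(-c3nn(CC(=O)NO)c4ncnc(N)c34)ccc2o1`, has not yet been measured. It differs from compound 1 in one place: hydroxycarbamoyl in place of 6-(methylcarbamoyl)hexyl on a saturated chain carbon bound to an aromatic nitrogen. Going by the values given here, compound 1 and compound 2 together offer no measured step that isolates this change. On that basis the step from compound 1 to compound 3 in this assay is expected to be a 1.8-fold higher number from compound 1 to compound 3 (0.25 log units; within the scatter), a modest loss of potency that may still fall within the scatter. Compound 3 is accordingly estimated at 15000 nM, within a range from 3000 nM to 60000 nM.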

Compound 3, half-maximal inhibitory concentration: 27700 nM
Estimate against measurement, compound 3: 1.8-fold (0.27 log units) below, within the range that was stated.
By their numbers in this assay, from the lowest: compounds 1 and 2 (each within the scatter of the next); then compound 3.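

In this assay, for the compounds shown here, the step of a 3.3-fold higher number from compound 1 to compound 3 (0.52 log units; beyond the scatter) is the first measured change at this place, on a saturated chain carbon bound to an aromatic nitrogen, and it shows that the number responds to what stands there: exchanging 6-(methylcarbamoyl)hexyl for hydroxycarbamoyl costs potency by a margin beyond the scatter, though the step remains modest. The loss is limited given the size of the change, as the entering group has fewer heavy atoms than the group that leaves, and compound 3 still gives a measurable number of 27700 nM on this read-out. Nothing measured here accounts for the step.

The step changes the length of the group and its terminal function together, so the compounds shown leave open how much of the loss belongs to either. A hexyl chain ending in hydroxycarbamoyl or in a carboxylic acid on the shared core would separate the two, and would show whether the number depends on chain length at this place.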